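The source may hold more compounds than are shown below. What is called first, only, known or untested is meant among the compounds shown, and "the series" means these compounds.

Compound 1 `NC(=O)c1ccc2c(ccn2-c2ccc(NC(=O)c3cccc(C(F)(F)F)c3)cc2)n1` and compound 3 `NC(=O)c1ccc2c(ccn2-c2ccc(NC(=O)c3ccc(Cl)c(C(F)(F)F)c3)cc2)n1` share one core and differ in a single place: chloro in place of hydrogen on an aromatic carbon. Compound 2 `COC(=O)c1ccc2c(ccn2-c2cccc(NC(=O)Nc3cccc(C(F)(F)F)c3)c2)n1` is built on a different core, and the difference between the two cores is not broken down here. Compound 4 `COC(=O)c1ccc2c(ccn2-c2cccc(NC(=O)Nc3ccc(Cl)c(C(F)(F)F)c3)c2)n1` stands to compound 2 as compound 3 stands to compound 1, carrying the change (chloro in place of hydrogen on an aromatic carbon). The place of the change reads the same way, word for word, for both pairs, so it is the same change, made twice among the compounds shown.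

In an ADME assay on HS27 cells (Homo sapiens) for cytotoxicity, read by MTT assay (on this read-out lower numbers stand for stronger inhibition and higher numbers for weaker inhibition), compound 1 gives > 10000 nM, which is a limit of the assay and not a number. In this assay compound 3 gives > 10000 nM, again a limit. The step that the two limits leave unreadable from compound 1 to compound 3 therefore has no readable size. In this assay compound 2 gives > 10000 nM, also a limit. All three results sit at the limit of > 10000 nM in this assay, at which 3 of the 3 values shown sit.

Compound 4 is expected to behave in the same way, because the limit of > 10000 nM in this assay, at which 3 of the 3 values shown sit, is where every measured compound here lands. The step that the limit leaves unreadable from compound 2 to compound 4 is expected to be one that the assay cannot resolve, since the same change already gave an unreadable step elsewhere. On this basis compound 4 is estimated at 20000 nM in this assay, with a range from 10000 nM to 60000 nM.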

Compound 4, half-maximal inhibitory concentration: > 10000 nM
Compound 4 was reported as a limit; the forecaster's own chance of this, stated with the estimate: 85%; the middle value lies beyond the limit too.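

In this assay compound 4 gives > 10000 nM, a limit of the assay and not a number. Compound 2 also sits at a limit, so no step can be read from compound 2 to compound 4, and the picture stays uniform: the limit of > 10000 nM in this assay, at which 4 of the 4 values shown sit.

Still open, going by these compounds, is how far each of the four compounds lies past that limit, and whether chloro in place of hydrogen changes the read-out at all.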